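Fluoro for amino on the phenoxy arm of compound 3

This account rests on a few compounds, and the source may have more. Where it says the series, first, only, none or still open, it means among the compounds named here.

Measured compounds:
compound 1 `O=c1cc(-n2cc(COc3ccccc3O)nn2)c2cc(Br)ccc2o1` gives 24800 nM in a functional assay on MCF7 cells (Homo sapiens) for antiproliferative activity, read by MTT assay, with a stated time of 48 h; a higher number here means a weaker inhibitor, a lower number a stronger inhibitor;
compound 2 `CCc1ccc(OCc2cn(-c3cc(=O)oc4ccc(Br)cc34)nn2)cc1` gives 12700 nM in this assay;
compound 3 `Nc1ccc(OCc2cn(-c3cc(=O)oc4ccc(Br)cc34)nn2)cc1` gives 2040 nM in this assay.

Compound 3 stands with the lowest number of the three, and its steps to both neighbours lie beyond the scatter: a 6.2-fold lower number from compound 2 to compound 3 (0.79 log units; beyond the scatter) and a 12-fold lower number from compound 1 to compound 3 (1.08 log units; beyond the scatter). Compound 4 `O=c1cc(-n2cc(COc3ccc(F)cc3)nn2)c2cc(Br)ccc2o1` differs from compound 3 by fluoro in place of amino on an aromatic carbon. Among the measured compounds shown here, the bearing step is the one from compound 2 to compound 3, where amino in place of ethyl gave a modest change of a 6.2-fold lower number from compound 2 to compound 3 (0.79 log units; beyond the scatter); the step of a 2.0-fold lower number from compound 1 to compound 2 (0.29 log units; within the scatter) lies within the scatter. Since the amino of compound 3 leaves in compound 4, a modest rise in number is expected, a 4.9-fold higher number from compound 3 to compound 4 (0.69 log units; beyond the scatter). Compound 4 is estimated at 10000 nM, in the range 4000 nM to 25000 nM.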

Compound 4, half-maximal inhibitory concentration: 7000 nM
Beside the measured number, compound 4's estimate is 1.4-fold (0.15 log units) above it; the measured number falls inside the stated range.
By their numbers in this assay, from the lowest: compound 3; then compounds 4, 2 and 1 (each within the scatter of the next, the first and the last beyond it).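

In this assay, the advantage of amino now holds against a second replacement, as fluoro in its place gives (a 3.4-fold higher number from compound 3 to compound 4 (0.54 log units; beyond the scatter)). Fluoro and ethyl at this place cannot be told apart (a 1.8-fold lower number from compound 2 to compound 4 (0.26 log units; within the scatter)), yet the 4-fluorophenyl arm separates from the 2-hydroxyphenyl arm (a 3.5-fold lower number from compound 1 to compound 4 (0.55 log units; beyond the scatter)), which the ethyl compound did not do. No measurement shown accounts for the standing of amino. The compounds shown leave open whether a hydroxyl, a methoxy or a dimethylamino group at this place would match amino.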